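From Fluoro to Chloro on the Core of Compound 2

A few compounds are considered here, and "the series" means these few. Any claim that something is new, unique, unknown or untested is made for them only; others in the source may bear on it.

Compound 2 `O=C(Nc1nc2ccc(F)cc2s1)c1cn(-c2ccccc2)nc1-c1ccccc1` holds the lowest of the two numbers in a functional assay on PC-3 cells (Homo sapiens) for cytotoxicity, read by MTT assay, with a stated time of 72 h (on this read-out lower numbers stand for stronger inhibition and higher numbers for weaker inhibition), at 3250 nM; its nearest neighbour, compound 1 `O=C(Nc1nc2ccccc2s1)c1cn(-c2ccccc2)nc1-c1ccccc1`, gives 10400 nM. Going by the values given here, the only measured step, a 3.2-fold lower number from compound 1 to compound 2 (0.51 log units; beyond the scatter), arose from fluoro in place of hydrogen on an aromatic carbon. Compound 3 `O=C(Nc1nc2ccc(Cl)cc2s1)c1cn(-c2ccccc2)nc1-c1ccccc1` differs from compound 2 by chloro in place of fluoro on an aromatic carbon, read one bond further out as 6-fluoro-1,3-benzothiazol-2-yl to 6-chloro-1,3-benzothiazol-2-yl. Among the compounds with values here, no measured step exchanges one halogen for another, so the author expects only a 1.3-fold lower number from compound 2 to compound 3 (0.11 log units; within the scatter), within the scatter. Compound 3 is estimated at 2500 nM, between 900 nM and 7000 nM.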

Compound 3, half-maximal inhibitory concentration: 3690 nM
The estimate for compound 3 lay 1.5-fold (0.17 log units) below the measured number, and the stated range covers the measured number.
By their numbers in this assay, from the lowest: compounds 2 and 3 (each within the scatter of the next); then compound 1.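

In this assay, exchanging one halogen for the other at this position gave a 1.1-fold higher number from compound 2 to compound 3 (0.06 log units; within the scatter) and so did not separate fluoro from chloro. Chloro in place of hydrogen gave a 2.8-fold lower number from compound 1 to compound 3 (0.45 log units; beyond the scatter) and so showed that the earlier gain with fluoro was not limited to that halogen among these compounds. No measurement shown here accounts for these numbers. The compounds shown leave open how a methoxy group, an amine or a carboxylic acid would read in place of the halogen on the 1,3-benzothiazol-2-yl group.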